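This account rests on a few compounds, and the source may have more. Where it says the series, first, only, none or still open, it means among the compounds named here.

Compound 1 `O=C1CN(Cc2ccc(-c3cccc(CN4CCCCC4)n3)cc2)C(=O)N1C1CC1`: 1.42 h
Compound 2 `CN1C(=O)CN(Cc2ccc(-c3cccc(CN4CCCCC4)n3)cc2)C1=O`: 1.5 h

Both values come from an in vitro ADME assay on microsomes from liver (Rattus norvegicus) for metabolic stability, read by LC-MS, using NADPH, tested at 1 uM; on this read-out lower numbers stand for a shorter-lived compound and higher numbers for a longer-lived compound. In this small set, compound 2 gives 1.5 h, which is level with compound 1 once the usual scatter of repeated measurements is taken into account. The next compound to consider is compound 3 `CC(C)N1C(=O)CN(Cc2ccc(-c3cccc(CN4CCCCC4)n3)cc2)C1=O`. It keeps the core of compound 2 and changes one group: isopropyl in place of methyl on an amide-type nitrogen in a ring. In words, isopropyl takes the place of methyl on an amide-type nitrogen in a ring.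

Within the data shown here, only one measured step bears on this change. It swaps cyclopropyl for methyl at that same kind of nitrogen: a 1.1-fold higher number from compound 1 to compound 2 (0.02 log units; within the scatter). That step stays within the scatter, so exchanging these groups at this place made no clear difference to the half-life. Still, a single pair is thin evidence, and isopropyl itself has not yet been measured here. The expectation is therefore for no step beyond the scatter, with a slight allowance for a shorter half-life. The estimated change is a 1.2-fold lower number from compound 2 to compound 3 (0.06 log units; within the scatter). The half-life expected for compound 3 is 1.3 h, within an estimated range of 0.7 h to 2.4 h.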

Compound 3, half-life in the Rattus norvegicus assay: 0.75 h
Estimate against measurement, compound 3: 1.7-fold (0.24 log units) above; the measured number falls inside the stated range.
By their numbers in the Rattus norvegicus assay, from the lowest: compounds 3, 1 and 2 (each within the scatter of the next).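

In the Rattus norvegicus assay, compound 3, with isopropyl on the amide-type nitrogen, gives 0.75 h, which is a 2.0-fold lower number from compound 2 to compound 3 (0.30 log units; within the scatter) and a 1.9-fold lower number from compound 1 to compound 3 (0.28 log units; within the scatter). With this third group, the comparison at this place now covers methyl, cyclopropyl and isopropyl rather than a single pair, and none of the steps among these three compounds lies beyond the scatter, so their half-lives cannot be told apart. Nothing measured here speaks to why the half-life responds this way at this position.

As far as these compounds go, in a physicochemical assay for acid dissociation, compound 2 gives 8.7, but the entry for compound 3 reads "not determined" (no result reported), so the step between them cannot be read, and whether isopropyl in place of methyl alters this read-out remains unknown. All three groups at this nitrogen contain only carbon and hydrogen, so the compounds shown leave open how the half-life would respond to a longer chain such as n-butyl, or to a chain carrying an amine or a carboxylic acid.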